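Cytotoxicity limits across the benzyl substituent changes

A few compounds are considered here, and "the series" means these few. Any claim that something is new, unique, unknown or untested is made for them only; others in the source may bear on it.

Compound 2 `N#Cc1cccc(CN2c3ccsc3C(=O)N(Cc3ccccc3)S2(=O)=O)c1` stands only at a limit: in an ADME assay on MT4 cells (Homo sapiens) for cytotoxicity, read by MTT assay, with a stated time of 4 days (on this read-out lower numbers stand for higher toxicity in this test and higher numbers for lower toxicity in this test), compound 2 gives > 305000 nM, a limit of the assay rather than a number. Compound 1 `O=C1c2sccc2N(Cc2cccc(Cl)c2)S(=O)(=O)N1Cc1ccccc1` likewise gives > 298000 nM in this assay, again a limit. The step that the two limits leave unreadable from compound 1 to compound 2 is therefore not readable, as the limit of > 298000 nM in this assay, at which 1 of the 2 values shown sits, and the limit of > 305000 nM in this assay, at which 1 of the 2 values shown sits, show. Compound 3 `O=C1c2sccc2N(Cc2ccc(Cl)cc2)S(=O)(=O)N1Cc1ccccc1` carries 4-chlorophenyl in place of 3-cyanophenyl on a saturated chain carbon bound to a sulfonamide nitrogen in a ring. No readable measured step bears on this change, so in this assay no step beyond the scatter is expected. Compound 3 is estimated at 300000 nM (range 150000 nM to 600000 nM). The expected step of an at least 1.0-fold lower number from compound 2 to compound 3 (0.00 log units; that floor lies within the scatter) most likely ends at a limit again.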

Compound 3, half-maximal cytotoxic concentration: 8200 nM
Compound 3: middle estimate off by 37-fold (1.56 log units), on the high side, outside the stated range (below it).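

Changing 3-chlorophenyl to 4-chlorophenyl at this place gives the first readable cytotoxicity in the series in this assay, with an at least 36-fold lower number from compound 1 to compound 3 (1.56 log units; beyond the scatter) and, against the nitrile, an at least 37-fold lower number from compound 2 to compound 3 (1.57 log units; beyond the scatter). Both steps are floors, since compound 1 stands at a limit: the limit of > 298000 nM in this assay, at which 1 of the 3 values shown sits. Compound 2 also stands at a limit: the limit of > 305000 nM in this assay, at which 1 of the 3 values shown sits.

Left open is whether this toxicity in this assay depends on the chlorine itself, or would persist with an amine or a carboxylic acid in its place.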